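Adding a hydroxy group to compound 2

The source may report more compounds than this note shows. Statements on the series, on what has been measured and on what is new or still open speak of the compounds shown alone.

Compound 2 (`CC(=O)Nc1ccc2oc(-c3ccc(F)cc3)cc(=O)c2c1`) gives 22000 nM in an ADME assay on THP-1 cells (Homo sapiens) for cytotoxicity, read by flow cytometry and propidium iodide staining, with a stated time of 72 h (on this read-out higher numbers stand for weaker inhibition and lower numbers for stronger inhibition), and stands above compound 3 (`CC(=O)Nc1ccc2oc(-c3ccc(C(F)(F)F)cc3)cc(=O)c2c1`), which gives 10000 nM on the same scale. Compound 1 (`CC(=O)Nc1ccc2oc(-c3cccc(F)c3)cc(=O)c2c1`) reads > 125000 nM in this assay and this is a limit of the assay, not a number.

Compound 4 (`CC(=O)Nc1ccc2oc(-c3ccc(F)cc3)c(O)c(=O)c2c1`) differs from compound 2 by a single change (hydroxy in place of hydrogen on an aromatic carbon) in which hydroxy stands in place of hydrogen on an aromatic carbon. Two measured steps are available as guides, and neither touches the carbon that takes the hydroxy. The first is an at least 5.6-fold lower number from compound 1 to compound 2 (0.75 log units; beyond the scatter) and rests on the limit of compound 1. Going by the values given here, the second is a 2.2-fold lower number from compound 2 to compound 3 (0.34 log units; beyond the scatter) and is the only step between two true numbers, so it is the better guide to size, though only a loose one. A modest step towards a lower number is therefore expected, with real doubt about its direction. The estimated change is a 1.8-fold lower number from compound 2 to compound 4 (0.26 log units; within the scatter) in this assay on this reasoning. For compound 4 the expected value is 12000 nM with an estimated range from 3000 nM to 50000 nM in this measurement.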

Compound 4, half-maximal inhibitory concentration: 26000 nM
For compound 4 the middle estimate is 2.2-fold (0.34 log units) below the measured one; the measured number falls inside the stated range.
By their numbers in this assay, from the lowest: compound 3; then compounds 2 and 4 (each within the scatter of the next). At a limit, above all of these: compound 1.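

In this assay, hydroxy in place of hydrogen on this aromatic carbon, ortho to a 4-fluorophenyl group and two atoms from the ring oxygen, gives a 1.2-fold higher number from compound 2 to compound 4 (0.07 log units; within the scatter), so the two compounds cannot be told apart on this read-out. Going by these compounds alone, the earlier steps, an at least 5.6-fold lower number from compound 1 to compound 2 (0.75 log units; beyond the scatter) and a 2.2-fold lower number from compound 2 to compound 3 (0.34 log units; beyond the scatter), were both changes on the phenyl substituent and both lay beyond the scatter, whereas this is the first reading of a change on the carbon itself, and for this one group, on this one background, the number stays within the scatter. Nothing in the data shown gives a cause for this result.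

The compounds shown leave open whether this carbon would take other groups as quietly, such as a methoxy group, an amine or a carboxylic acid, since hydroxy is the only group seen here in place of hydrogen. They also leave open whether the same hydroxy would give a step of the same size on the 4-(trifluoromethyl)phenyl background of compound 3, where the reading is 10000 nM.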